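Thiophene in Place of Furan: Expected Antiproliferative Potency

The source may hold more compounds than are shown below. What is called first, only, known or untested is meant among the compounds shown, and "the series" means these compounds.

Measured compounds:
Compound 1, `Oc1c(C(c2ccco2)c2ccc3cccnc3c2O)ccc2cccnc12`: in a functional assay on KB cells (Homo sapiens) for antiproliferative activity (a higher number here means a weaker inhibitor, a lower number a stronger inhibitor), compound 1 gives < 0.3 ug/mL, which is a limit of the assay rather than a number.
Compound 2, `COc1ccc(C(c2ccc3cccnc3c2O)c2oc(CO)cc(=O)c2O)cc1`: in this assay compound 2 gives < 0.3 ug/mL, again a limit rather than a number.

Compound 1 therefore stands at the assay limit, and nothing finer can be said of its place: both values shown sit at the limit of < 0.3 ug/mL in this assay, at which 2 of the 2 values shown sit, so no spread between the two compounds is visible. Going by the values given here, no step between two measured compounds exists in this set.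

The unmeasured compound 3, `Oc1c(C(c2cccs2)c2ccc3cccnc3c2O)ccc2cccnc12`, differs from compound 1 by one change: thiophen-2-yl in place of furan-2-yl on a saturated chain carbon bound to two aromatic carbons. The central carbon, the hydroxylated rings attached to it and everything else are kept.

Among the compounds with values here, with two compounds sitting at the same limit there is no measured step to lean on. The change is small in size and kind, and no effect beyond the scatter is expected in this assay. For compound 3 the expected step is a step that the limit leaves unreadable from compound 1 to compound 3. Compound 3 is accordingly estimated at 0.15 ug/mL, within a range from 0.03 ug/mL to 0.6 ug/mL, most likely again reported as a limit.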

Compound 3, half-maximal inhibitory concentration: < 0.3 ug/mL
Compound 3: no number, only a limit (the forecaster's own chance of this, stated with the estimate: 70%); the middle value does not contradict the limit.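

In this assay compound 3 gives < 0.3 ug/mL, a limit of the assay and not a number. Compound 1 also stands at a limit, so no step between compound 1 and compound 3 can be read: the limit of < 0.3 ug/mL in this assay, at which 3 of the 3 values shown sit.

What stays open is whether thiophen-2-yl in place of furan-2-yl changes the potency at all, and how strong each of these compounds really is.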